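Swapping a Second Bromo for Hydrogen in Compound 1

The source may report more compounds than this note shows. Statements on the series, on what has been measured and on what is new or still open speak of the compounds shown alone.

- Compound 1 `O=C(Nc1cccc(Cl)c1)c1cc(Br)cc(Br)c1O` gives 18000 nM
- Compound 2 `O=C(Nc1cccc(Cl)c1)c1cc(Br)cc(Br)c1` gives 53000 nM
- Compound 3 `O=C(Nc1cccc(Cl)c1)c1cccc(Br)c1O` gives 32000 nM

These values come from an ADME assay on HEK293 cells (Homo sapiens) for cytotoxicity, read by reporter gene assay and resazurin assay, with a stated time of 48 h; on this read-out lower numbers stand for higher toxicity in this test and higher numbers for lower toxicity in this test. Compound 1 stands at the more toxic end of this small set, although compound 3 cannot be told apart from it: the measured change is a 1.8-fold higher number from compound 1 to compound 3 (0.25 log units; within the scatter). Compound 2 sits clearly further off, with a 2.9-fold higher number from compound 1 to compound 2 (0.47 log units; beyond the scatter).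

The open question concerns compound 4 `O=C(Nc1cccc(Cl)c1)c1cc(Br)ccc1O`, whose structure differs from that of compound 1 as follows: hydrogen in place of bromo on an aromatic carbon. In words, this is hydrogen in place of bromo on an aromatic carbon, ortho to a hydroxy group.

Within the data shown here, compound 3 offers the closest precedent, as it carries the same kind of swap at the other bromo, and that swap gave a 1.8-fold higher number from compound 1 to compound 3 (0.25 log units; within the scatter). The step to compound 2 replaces the hydroxy group instead, so it bears on this change only loosely. The data do not show whether the two bromo groups count alike. A small rise in the number is therefore expected, probably no larger than the scatter, and the expected step is a 1.7-fold higher number from compound 1 to compound 4 (0.22 log units; within the scatter).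

For compound 4 the estimate is 30000 nM, with an expected range from 14000 nM to 65000 nM.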

Compound 4, half-maximal cytotoxic concentration: 15000 nM
Compound 4: middle estimate off by 2.0-fold (0.30 log units), on the high side; low and high end bracket the measured number.
By their numbers in this assay, from the lowest: compounds 4, 1, 3 and 2 (each within the scatter of the next, the first and the last beyond it).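

In this assay, the bromo ortho to a hydroxy group can be replaced by hydrogen with no readable effect, as the result is a 1.2-fold lower number from compound 1 to compound 4 (0.08 log units; within the scatter). This adds a second bromo position to the earlier swap, a 1.8-fold higher number from compound 1 to compound 3 (0.25 log units; within the scatter), which also stayed within the scatter, so in these two compounds neither single bromo replacement separates clearly from compound 1, whereas replacing the hydroxy group gave a 2.9-fold higher number from compound 1 to compound 2 (0.47 log units; beyond the scatter). The compounds shown offer no independent measurement that would explain why this position tolerates the loss of bromo.

The compounds shown leave open whether the two bromo groups act independently, since no compound here carries hydrogen at both positions, and a small effect at either position could still lie hidden within the scatter. Among these compounds, they also leave open how this position responds to anything other than bromo or hydrogen, such as an amine, a methoxy group or a carboxylic acid, so the present result describes only this one exchange on the core of compound 1.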